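Swapping carbamoyl for hydroxy on compound 3

This account rests on a few compounds, and the source may have more. Where it says the series, first, only, none or still open, it means among the compounds named here.

- Compound 1 `CC(=O)c1ccc(NC(=O)Nc2cc(C)nc3ccccc23)cc1` gives 22000 nM
- Compound 2 `Cc1cc(NC(=O)Nc2ccccc2N)c2ccccc2n1` gives > 25000 nM (a limit)
- Compound 3 `Cc1cc(NC(=O)Nc2ccc(C(N)=O)cc2)c2ccccc2n1` gives > 25000 nM (a limit)

These values come from an ADME assay on BJ cells (Homo sapiens) for cytotoxicity, with a stated time of 72 h (on this read-out higher numbers stand for an effect only at larger amounts of compound and lower numbers for an effect already at smaller amounts), and are the only ones so far. Compound 3 stands at the limit of > 25000 nM in this assay, at which 2 of the 3 values shown sit, and so has no exact number. Compound 4 `Cc1cc(NC(=O)Nc2ccc(O)cc2)c2ccccc2n1` carries hydroxy in place of carbamoyl on an aromatic carbon. Among the measured compounds shown here, the only measured step that alters this same group (an at least 1.1-fold higher number from compound 1 to compound 3 (0.05 log units; that floor lies within the scatter)) stays within the scatter and gives only a floor for its size. No step beyond the scatter is therefore expected in either direction, and the estimated change is small (a number no higher from compound 3 to compound 4 (the limit leaves the size open)). Compound 4 is expected at 25000 nM (estimated range 10000 nM to 60000 nM).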

Compound 4, half-maximal effective concentration: > 25000 nM
Compound 4: a limit, no number; the forecaster's own chance of this, stated with the estimate: 60%; the middle value lies on the limit itself.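

In this assay, putting hydroxy in place of acetyl on this aromatic carbon, para to a large group, gives an at least 1.1-fold higher number from compound 1 to compound 4 (0.05 log units; that floor lies within the scatter) and so shows only a small floor, not the true size of the step. Hydroxy has 1 heavy atom and carbamoyl has 3, yet compound 4, like compound 3, gives a limit and no number. The steps to compound 4 from compound 3 and from compound 2 cannot be read, since both ends of each are limits: the limit of > 25000 nM in this assay, at which 3 of the 4 values shown sit.

From the compounds shown here alone, whether an amine or a carboxylic acid on this carbon would give an exact number stays open. So does how far the true values of compound 3 and compound 4 lie beyond their limit.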